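The compounds below may be only part of what the source reports. "The series", "measured", "known", "first", "only" and "open" are said of these compounds alone.

- Compound 1 `C#CCN(Cc1ccc2nc(N)nc(O)c2c1)c1ccc(C(=O)NC(CC)C(=O)OCC)cc1`: 52 uM
- Compound 2 `C#CCN(Cc1ccc2nc(N)nc(O)c2c1)c1ccc(C(=O)O)cc1`: > 200 uM

The two compounds were tested in a functional assay on L1210 cells (Mus musculus) for inhibition; a lower number here means a stronger inhibitor, a higher number a weaker inhibitor. Compound 2 stands at > 200 uM, which is a limit and not a number. Compound 3 `C#CCN(Cc1ccc2nc(N)nc(O)c2c1)c1ccc(CCCC(=O)O)cc1` carries 3-carboxypropyl in place of carboxy on an aromatic carbon, para to a large group: 3-carboxypropyl in place of carboxy on an aromatic carbon. For the measured compounds named here, the only measured step, an at least 3.8-fold higher number from compound 1 to compound 2 (0.58 log units; beyond the scatter), also changes the carboxy end of the molecule, but it does not lengthen a chain and is only a loose guide. Compound 1 at 52 uM shows that a number can be reached with this core, so a modest step to a lower number in this assay is expected, though no real change is also possible. The expected step is an at least 1.5-fold lower number from compound 2 to compound 3 (0.18 log units; that floor lies within the scatter). For compound 3 the estimated value is 130 uM, with an expected range of 40 uM to 300 uM.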

Compound 3, concentration for 50% inhibition: > 10 uM
Compound 3 ended at the assay's limit (the forecaster's own chance of this, stated with the estimate: 45%); the middle value lies beyond the limit too.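

In this assay compound 3 gives > 10 uM, which is a limit and not a number. Compound 2 also stands at a limit, > 200 uM. For the compounds shown here, no step from compound 1 or compound 2 to compound 3 can be read. The compounds shown leave open whether, and in which direction, 3-carboxypropyl in place of carboxy changes the result in this assay.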